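The source may report more compounds than this note shows. Statements on the series, on what has been measured and on what is new or still open speak of the compounds shown alone.

Measured in a functional assay on OVCAR-5 cells (Homo sapiens) for inhibition, read by sulforhodamine B assay, with a stated time of 48 h; a higher number here means a weaker inhibitor of growth, a lower number a stronger inhibitor of growth:

- compound 1 `CN(C)/C=C/C(=O)c1nn(-c2ccccc2)c(-c2ccccc2)c1C#N`: > 100000 nM
- compound 2 `Cc1nnc(-c2nn(-c3ccccc3)c(-c3ccccc3)c2C#N)c2cn(-c3ccccc3)nc12`: > 100000 nM

Both readings are limits of the assay and not numbers. Compound 1 gives only a limit. Compound 2 also gives only a limit, and it stands with the other measured compound on (the limit of > 100000 nM in this assay, at which 2 of the 2 values shown sit). Within the data shown here, the series therefore holds no measured step so far.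

The next compound is compound 3 `N#Cc1c(-c2nnc(O)c3nn(-c4ccccc4)cc23)nn(-c2ccccc2)c1-c1ccccc1`. Against compound 2, it has hydroxy in place of methyl on an aromatic carbon of a six-membered aromatic ring with 2 nitrogen, part of a fused or bridged system of two rings (hydroxy in place of methyl on an aromatic carbon). The rest of the structure is the same.

The expected step in this assay is small, with an at least 1.1-fold lower number from compound 2 to compound 3 (0.04 log units; that floor lies within the scatter) estimated, and nothing beyond the scatter is expected. This expectation rests on compound 2, whose > 100000 nM is a limit. A report of a limit alone is the most likely outcome for the next reading.

Compound 3 is estimated at 90000 nM, with an expected range of 30000 nM to 100000 nM.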

Compound 3, concentration for 50% growth inhibition: 61800 nM
Compound 3: middle estimate off by 1.5-fold (0.16 log units), on the high side; low and high end bracket the measured number.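

In this assay, among these compounds, compound 3 gives 61800 nM, the first reading that is a number and not a limit, so this position, on an aromatic carbon next to the ring nitrogen, can carry a hydroxy group with growth inhibition coming into the measurable range. Hydroxy in place of methyl gives an at least 1.6-fold lower number from compound 2 to compound 3 (0.20 log units; that floor lies within the scatter), and that figure is only a floor for the change. Compound 2 holds a limit and not a number, so the true size of the step stays unknown and may exceed the floor: the limit of > 100000 nM in this assay, at which 2 of the 3 values shown sit.

Going by these compounds, whether an amine or a methoxy group on the same aromatic carbon would read like hydroxy or like methyl remains open, as does the effect of changing the nitrile or the phenyl groups of the shared core. With a single measured number in the series no trend can be stated, and compound 1 differs from the other two compounds in more than one place, so it offers no comparison at this position.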